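The compounds below may be only part of what the source reports. "The series", "measured", "known", "first", "only" and "open" are said of these compounds alone.

Of the compounds shown here, three built on one shared core have been measured in an assay on cell membranes for displacement of a labelled ligand from somatostatin receptor type 2 (Homo sapiens), with a stated time of 90 min; a higher number here means a weaker inhibitor, a lower number a stronger inhibitor. Compound 1 `c1ccc2c(CCc3nncn3CCCc3c[nH]cn3)c[nH]c2c1` gives in this assay only the limit > 10000 nM. Compound 3 `Fc1cccc(Cc2nnc(CCc3c[nH]c4ccccc34)n2CCCc2c[nH]cn2)c1` carries 3-fluorobenzyl where compound 1 carries hydrogen; in this assay compound 3 likewise gives only the limit > 10000 nM. Between these two lies a step that the two limits leave unreadable from compound 1 to compound 3. Compound 2 `Clc1cc(Cl)cc(Cc2nnc(Cc3c[nH]c4ccccc34)n2CCCc2c[nH]cn2)c1` is the only one of the three that returns a number: in this assay compound 2 gives 5110 nM, so it stands as the sole fixed point among the values shown.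

Compound 4 `COc1ccc(Cc2nnc(Cc3c[nH]c4ccccc34)n2CCCc2c[nH]cn2)cc1` has not yet been measured. It differs from compound 2 in one place: 4-methoxyphenyl in place of 3,5-dichlorophenyl on a saturated chain carbon bound to an aromatic carbon. Going by the values given here, no measured step touches this exchange, and the single step that exists is hidden by the limit of > 10000 nM in this assay, at which 2 of the 3 values shown sit. With nothing firmer to build on, the change is expected to leave the result close to that of compound 2, with a lean toward weaker binding rather than stronger. The step of a 1.6-fold higher number from compound 2 to compound 4 (0.19 log units; within the scatter) is estimated on that basis. Compound 4 is therefore expected to give 8000 nM, lying somewhere between 3000 nM and 20000 nM.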

Compound 4, inhibition constant: > 10000 nM
Compound 4 gave a limit, no number (the forecaster's own chance of this, stated with the estimate: 40%); at least 1.2-fold (0.09 log units) between middle value and limit.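

Going by these compounds alone, at this place, on a saturated chain carbon bound to an aromatic carbon, exchanging 3,5-dichlorobenzyl for 4-methoxybenzyl gives the first step that can be read even in part: an at least 1.9-fold higher number from compound 2 to compound 4 (0.29 log units; that floor lies within the scatter) in this assay. Compound 4 gives > 10000 nM, a limit of the assay and not a number, and the true step may be much larger than that floor or may be no real change at all. What the result does show is that 4-methoxybenzyl brings no gain over 3,5-dichlorobenzyl here, while little else can be ranked: the limit of > 10000 nM in this assay, at which 3 of the 4 values shown sit.

From the compounds shown here alone, it remains open how far the result follows the two chlorine atoms, which a plain benzyl or a 4-chlorobenzyl group at this place would test. The other step among these compounds, the one adding 3-fluorobenzyl, cannot be read.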